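Methyl added on the amine of compound 3

The source may hold more compounds than are shown below. What is called first, only, known or untested is meant among the compounds shown, and "the series" means these compounds.

Measured so far:
- compound 1, `CCC(C)NC1=NS(=O)(=O)c2cc(F)ccc2N1`: in a functional assay (aorta) with Rattus norvegicus as the target (a higher number here means that more compound is needed for the effect, a lower number that less compound is needed), compound 1 gives 39.2 uM
- compound 2, `CC(C)C(C)NC1=NS(=O)(=O)c2cc(F)ccc2N1`: compound 2 gives 26.4 uM
- compound 3, `CNC1=NS(=O)(=O)c2cc(Br)ccc2N1`: compound 3 gives 31 uM

All three values lie close together, and none of the compounds can be called the strongest or weakest on this evidence. Going by the values given here, the one change that is measured twice in this set is a small one: methyl in place of hydrogen on a saturated chain carbon bound to two saturated chain carbons, which gave a 1.5-fold lower number from compound 1 to compound 2 (0.17 log units; within the scatter).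

Compound 4, `CCNC1=NS(=O)(=O)c2cc(Br)ccc2N1`, has not yet been measured. It differs from compound 3 by methyl in place of hydrogen on a saturated chain carbon bound to an amine nitrogen. Among the compounds with values here, this is the same kind of change as the one from compound 1 to compound 2, but not the same: there the methyl enters on a saturated chain carbon bound to two saturated chain carbons, here on a saturated chain carbon bound to an amine nitrogen. How the core of compound 3 differs from the core of compound 1 is not broken down here.

The expectation for compound 4 rests on the earlier step, because a 1.5-fold lower number from compound 1 to compound 2 (0.17 log units; within the scatter) stayed within the scatter, so a step of about a 1.2-fold lower number from compound 3 to compound 4 (0.08 log units; within the scatter) is expected. For compound 4 the estimated value in this assay is 26 uM, expected to fall between 12 uM and 55 uM.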

Compound 4, concentration for half-maximal effect: 6.2 uM
The estimate for compound 4 lay 4.2-fold (0.62 log units) above the measured number; the whole stated range lies above it.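

In this assay, adding one methyl gave a 5.0-fold lower number from compound 3 to compound 4 (0.70 log units; beyond the scatter), so on this core a single added carbon made a clear difference. Set beside the earlier step, the change did not carry over at the same size: the same change on two cores in this assay, a 1.5-fold lower number (0.17 log units; within the scatter) from compound 1 to compound 2 and a 5.0-fold lower number (0.70 log units; beyond the scatter) from compound 3 to compound 4, 3.4-fold (0.53 log units) apart, beyond the scatter of two such steps This does not show which difference between the two steps matters, since they differ in their cores and also in where the methyl enters, on a saturated chain carbon bound to two saturated chain carbons in one and on a saturated chain carbon bound to an amine nitrogen in the other, and a single pair on each core cannot separate the two.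

Still open, going by these compounds, is whether a longer chain on the amine, such as propyl or butyl, would lower the number further than ethyl does on the core of compound 4. Also open, on these data alone, is whether going from methylamino to ethylamino on the core of compound 1 would give a step of similar size.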